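Branching the acyl chain on a piperidine amide

A few compounds are considered here, and "the series" means these few. Any claim that something is new, unique, unknown or untested is made for them only; others in the source may bear on it.

Compound 2 `CCCC(=O)N1CCC(CN(C2Cc3cc(C#N)ccc3N(Cc3cncn3C)C2)S(=O)(=O)c2ccccn2)CC1` is one of three close analogues that share a core and differ only in the group on a carbonyl carbon. In an ADME assay on Caco-2 cells (Homo sapiens) for permeability, in the apical to basolateral direction (on this read-out higher numbers stand for higher permeability and lower numbers for lower permeability), compound 2 gives 0.5 10^-6 cm/s. Compound 1 `Cn1cncc1CN1CC(N(CC2CCN(C(=O)c3ccccc3)CC2)S(=O)(=O)c2ccccn2)Cc2cc(C#N)ccc21`, carrying a phenyl on that carbonyl carbon, gives 0.5 10^-6 cm/s, and compound 3 `C=C(C)C(=O)N1CCC(CN(C2Cc3cc(C#N)ccc3N(Cc3cncn3C)C2)S(=O)(=O)c2ccccn2)CC1`, carrying a 1-methylethenyl there, gives 0.5 10^-6 cm/s. Compound 2 therefore stands level with both neighbours, and the steps of no change at the digits printed from compound 1 to compound 2 (within the scatter), no change at the digits printed from compound 1 to compound 3 (within the scatter) and no change at the digits printed from compound 2 to compound 3 (within the scatter) all stay within the scatter.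

Compound 4 `CC(C)C(=O)N1CCC(CN(C2Cc3cc(C#N)ccc3N(Cc3cncn3C)C2)S(=O)(=O)c2ccccn2)CC1` has not yet been measured. It differs from compound 2 by isopropyl in place of propyl on a carbonyl carbon, the two having the same atoms joined differently. The three measured steps bear on this change, since each of them swaps the group on the same carbonyl carbon, and none of them moved the read-out beyond the scatter, whether the group was phenyl, propyl or 1-methylethenyl. The account therefore expects no step beyond the scatter for compound 4, so that no change at the digits printed from compound 2 to compound 4 (within the scatter) is estimated to be essentially flat. On that basis compound 4 is expected to give about 0.5 10^-6 cm/s in this assay, with a likely range from 0.25 10^-6 cm/s to 1 10^-6 cm/s.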

Compound 4, apparent permeability: 0.5 10^-6 cm/s
Estimate against measurement, compound 4: no gap at the digits printed, and the stated range covers the measured number.
By their numbers in this assay, from the lowest: compounds 1, 2, 3 and 4 (each within the scatter of the next).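

Swapping propyl for isopropyl on the carbonyl carbon, with the same atoms joined differently, gives in this assay no change at the digits printed from compound 2 to compound 4 (within the scatter), so this position has now been tested for how a chain of the same atoms is joined as well as for which group it carries. The comparisons with the other two groups read the same, with no change at the digits printed from compound 3 to compound 4 (within the scatter) and no change at the digits printed from compound 1 to compound 4 (within the scatter), which places phenyl, propyl, 1-methylethenyl and isopropyl all within the scatter of one another, with no group standing apart from the rest. No measured evidence bears on why the read-out stays flat across these groups.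

All four groups are built only of carbon and hydrogen, so the compounds shown leave open whether an amine, a carboxylic acid or a longer chain on this carbonyl carbon would move the read-out beyond the scatter. They also leave open whether replacing the nitrile on the shared core would shift a level that stands, for compound 4, at 0.5 10^-6 cm/s.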